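The source may report more compounds than this note shows. Statements on the series, on what has been measured and on what is new or still open speak of the compounds shown alone.

Three compounds share one core and were tested in a functional assay on Malme-3M cells (Homo sapiens) for cytotoxicity, read by sulforhodamine B assay, with a stated time of 48 h, tested at 100 uM; a higher number here means a weaker effect of the compound at the concentration tested, a lower number a stronger effect. Compound 1, with the structure `COc1cc(-c2cc(/C=C/C(=O)c3ccc(Cl)c(Cl)c3)[nH]n2)cc(OC)c1OC`, gives 24% in this assay. Compound 2, with the structure `COc1ccc(-c2cc(/C=C/C(=O)c3cc(OC)c(OC)c(OC)c3)[nH]n2)cc1OC`, gives -62%. Compound 3, with the structure `COc1cc(C(=O)/C=C/c2cc(-c3cc(OC)c(OC)c(OC)c3)n[nH]2)cc(OC)c1OC`, gives -94%. Compound 1 therefore stands highest of the three numbers, meaning the weakest effect at the tested concentration; the nearest number is that of compound 2 and the furthest that of compound 3, both gaps beyond the scatter. Among the measured compounds shown here, the one step between measured compounds that differ in a single place is a number 32 percentage points lower from compound 2 to compound 3 (beyond the scatter).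

Compound 4, with the structure `COc1cc(-c2cc(/C=C/C(=O)c3ccc(F)c(F)c3)[nH]n2)cc(OC)c1OC`, differs from compound 1 in one place: 3,4-difluorophenyl in place of 3,4-dichlorophenyl on a carbonyl carbon. For the measured compounds named here, no measured step concerns a 3,4-difluorophenyl in place of a 3,4-dichlorophenyl; the single step known, a methoxy in place of a hydrogen, does not bear on it. With nothing to set a direction, the expected step is a number 6 percentage points higher from compound 1 to compound 4 (within the scatter), that is, none beyond the scatter. Compound 4 is therefore estimated to give 30% in this assay, with a range from 0% to 60%.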

Compound 4, a percentage reported as activity, at one concentration (the size of the read-out at that concentration, not a potency): -31%
Compound 4: the middle estimate sits 61 percentage points above what was measured; the whole stated range lies above it.
By their numbers in this assay, from the lowest: compound 3; then compound 2; then compound 4; then compound 1.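

The group on the carbonyl carbon matters in this series: with 3,4-difluorophenyl in place of 3,4-dichlorophenyl, this assay shows a number 55 percentage points lower from compound 1 to compound 4 (beyond the scatter). The size of this step is notable, as the two groups have the same count of heavy atoms and neither has hydrogen-bond donors or acceptors, so the change lies only in which halogen the ring carries. Among the compounds shown here, the only earlier step concerned a methoxy in place of a hydrogen, so this is the first sign that this position also responds to substitution, although no measurement here explains why.

The compounds shown leave open how a plain phenyl, a 3,4-dibromophenyl or a phenyl bearing an amine would behave on this carbonyl carbon. They also leave open whether the halogen swap would have a similar effect alongside a different methoxy pattern on the other ring.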